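Fixing the Stereocentre of Compound 3

The compounds below may be only part of what the source reports. "The series", "measured", "known", "first", "only" and "open" are said of these compounds alone.

Three measured compounds share one core. Compound 1 `CC(=O)N1N=C(c2ccc([N+](=O)[O-])cc2)O[C@@H]1c1ccc(Cl)c(Cl)c1` carries a nitro group on one ring, and in an assay on BTI cells for inhibition of Amine oxidase [flavin-containing] B (Homo sapiens), read by fluorescence and Amplex Red, with a stated time of 15 min (on this read-out lower numbers stand for stronger inhibition and higher numbers for weaker inhibition), compound 1 gives 7.61 nM. Compound 2 `CC(=O)N1N=C(c2ccncc2)OC1c1ccc(Cl)c(Cl)c1` gives 69400 nM, and compound 3 `CC(=O)N1N=C(c2ccc(Cl)cc2)OC1c1ccc(Cl)c(Cl)c1` gives 627 nM. Going by the values given here, compound 3 thus stands second highest of the three numbers: compound 1 sits far lower, compound 2 far higher, and the single step between them, a 110-fold lower number from compound 2 to compound 3 (2.04 log units; beyond the scatter), shows how strongly the ring on the carbon with a double bond to nitrogen can shift the number.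

Compound 4 `CC(=O)N1N=C(c2ccc(Cl)cc2)O[C@@H]1c1ccc(Cl)c(Cl)c1` differs from compound 3 in a different way: the two compounds have the same atoms and bonds; at least one stereo element is drawn with a configuration in one of them and without one in the other: 1 of 1 stereo elements differ; a stereocentre at a saturated ring carbon is drawn without a configuration in compound 3 and R in compound 4. Among the compounds with values here, no measured step is of this kind; the one step available concerns a ring exchange and says nothing about drawing a configuration. Compound 1, drawn R, does show that the R form of this core can reach a low number. Where a drawing without a configuration can mean that both forms are present, singling out the R form is expected to move the number only modestly, a 2.1-fold lower number from compound 3 to compound 4 (0.32 log units; beyond the scatter), toward a lower value. Compound 4 is therefore estimated at 300 nM, with a range from 120 nM to 900 nM.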

Compound 4, half-maximal inhibitory concentration: 204 nM
For compound 4 the middle estimate is 1.5-fold (0.17 log units) above the measured one; the measured number falls inside the stated range.
By their numbers in this assay, from the lowest: compound 1; then compound 4; then compound 3; then compound 2.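

Drawing the saturated ring carbon as R comes with a 3.1-fold lower number from compound 3 to compound 4 (0.49 log units; beyond the scatter) in this assay, a modest step but the first of its kind here, since the earlier compounds offered only a ring exchange. With compound 4 drawn R like compound 1, the two can now be set side by side at the same configuration, and that gives a 27-fold higher number from compound 1 to compound 4 (1.43 log units; beyond the scatter), so exchanging one group on the ring moves the number much further than fixing the stereocentre does. The step from compound 3 can be tied to this one carbon because the two structures have nothing else to separate them: the fact that one of compounds 3 and 4 is drawn with a defined configuration and the other without, at the place where they differ

Going by these compounds, what remains open is how the S form of this core would read, and whether compound 3 really holds both forms, since a drawing without a configuration only can mean that. Also unanswered is whether an amine or a methoxy group in place of chloro on an aromatic carbon would land nearer compound 1 or compound 4.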